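Hydroxybutyl for phenyl: cytotoxicity notes on the series

The compounds below may be only part of what the source reports. "The series", "measured", "known", "first", "only" and "open" are said of these compounds alone.

Measured so far in an ADME assay on 184B5 cells (Homo sapiens) for cytotoxicity, read by MTT assay, with a stated time of 72 h; a lower number here means a stronger inhibitor of growth, a higher number a weaker inhibitor of growth:
Compound 1 `CSc1nc(NCCCCCO)c2cccnc2n1` gives only a limit, > 100000 nM.
Compound 2 `CSc1nc(NCc2ccccc2)c2ccccc2n1` gives 28900 nM.
Compound 3 `CSc1nc(NCc2ccccc2)c2cccnc2n1` gives 49000 nM.

Compound 2 holds the lowest number of the two measured, though compound 3 sits within the scatter of it. The difference between the two cores is not broken down here. From compound 3 to compound 1 the change is 4-hydroxybutyl in place of phenyl on a saturated chain carbon bound to a nitrogen on an aromatic ring, and in this assay it gave an at least 2.0-fold higher number from compound 3 to compound 1 (0.30 log units; that floor lies within the scatter), the end point being a limit (the limit of > 100000 nM in this assay, at which 1 of the 3 values shown sits).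

Compound 4 `CSc1nc(NCCCCCO)c2ccccc2n1` is the same kind of change on the core of compound 2: 4-hydroxybutyl in place of phenyl on a saturated chain carbon bound to a nitrogen on an aromatic ring. Compound 4 is expected to show a step of a 2.8-fold higher number from compound 2 to compound 4 (0.44 log units; beyond the scatter), resting on the direction seen for compound 1 an at least 2.0-fold higher number from compound 3 to compound 1 (0.30 log units; that floor lies within the scatter). Compound 4 is therefore estimated at 80000 nM in this assay, between 35000 nM and 200000 nM.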

Compound 4, concentration for 50% growth inhibition: 49900 nM
Estimate against measurement, compound 4: 1.6-fold (0.20 log units) above, and the stated range covers the measured number.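

Replacing phenyl with 4-hydroxybutyl on the second core gives, in this assay, a 1.7-fold higher number from compound 2 to compound 4 (0.24 log units; within the scatter). Set beside the earlier step, this neither shows that the change carries over unaltered from one core to the other nor shows that the two cores respond differently: the same change on two cores in this assay, an at least 2.0-fold higher number (0.30 log units; that floor lies within the scatter) from compound 3 to compound 1 and a 1.7-fold higher number (0.24 log units; within the scatter) from compound 2 to compound 4; the limit leaves it open whether they differ

Compound 1 gives only a limit, > 100000 nM, and neither step lies clearly beyond the scatter, so no firm transfer of the change is established.

Still open, on these data alone, is whether a chain ending in an amine or a carboxylic acid, in place of the hydroxyl end, would read alike on both cores. A longer chain, or a substituted phenyl, is equally untested among the compounds shown.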